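Swapping a Nitro Group for Chlorine on a Hydrazone

The source may hold more compounds than are shown below. What is called first, only, known or untested is meant among the compounds shown, and "the series" means these compounds.

Two hydrazones built on the same trimethoxybenzoyl core have been tested in a functional assay on PC-3 cells (Homo sapiens) for antiproliferative activity, read by MTT assay, tested at 5 uM; on this read-out higher numbers stand for a stronger effect at the one concentration tested and lower numbers for a weaker effect. Compound 1 `COc1cc(C(=O)N/N=C/c2cccc(F)c2)cc(OC)c1OC` gives 64.1%. Compound 2 `COc1cc(C(=O)N/N=C/c2ccc(Cl)c([N+](=O)[O-])c2)cc(OC)c1OC` gives 42.3%, the lower of the two numbers, and its gap to compound 1 lies beyond the usual scatter. Compound 3 `COc1cc(C(=O)N/N=C/c2ccc(Cl)c(Cl)c2)cc(OC)c1OC` differs from compound 2 in one place: chloro in place of nitro on an aromatic carbon. For the measured compounds named here, no measured pair shows this exact change, so the expected step from compound 2 to compound 3 is given cautiously. The step of a number 5.7 percentage points higher from compound 2 to compound 3 (within the scatter) is expected to be small, within the scatter. Compound 3 is expected to give 48%, within 30% to 68%.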

Compound 3, a percentage reported as inhibition, at one concentration (the size of the read-out at that concentration, not a potency): 31.6%
Beside the measured number, compound 3's estimate is 16.4 percentage points above it; low and high end bracket the measured number.
By their numbers in this assay, from the lowest: compound 3; then compound 2; then compound 1.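

In this assay, chloro in place of nitro on this aromatic carbon is not a neutral swap: the step (a number 10.7 percentage points lower from compound 2 to compound 3 (beyond the scatter)) shows that the two groups are not interchangeable here. The change of 3,4-dichlorophenyl in place of 3-fluorophenyl gives a larger step (a number 32.5 percentage points lower from compound 1 to compound 3 (beyond the scatter)), so the read-out also depends strongly on the wider pattern on this ring. Nothing measured here explains either step. Still open, as far as these compounds go, is where an amine or a carboxylic acid at this place would fall relative to nitro and chloro. Also open, from the compounds shown here alone, is how these compounds compare at other concentrations.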